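The source may report more compounds than this note shows. Statements on the series, on what has been measured and on what is new or still open speak of the compounds shown alone.

Of the compounds shown here, three sharing one core have been measured in an ADME assay on microsomes from liver (Homo sapiens) for metabolic stability, read by LC-MS, using NADPH, with a stated time of 10 min, tested at 0.1 uM; a higher number here means faster removal of the compound, a lower number slower removal. Compound 1 `COc1ccc(F)cc1N1C(=O)CSC1c1cccc(C(=O)NCCCCn2cccn2)c1` gives 421 mL.min-1.g-1, and compound 2 `Cc1ccnc(N2C(=O)CSC2c2cccc(C(=O)NCCCCn3cccn3)c2)c1` gives 129 mL.min-1.g-1. Compound 3 `O=C(NCCCCc1ccccc1)c1cccc(C2SCC(=O)N2c2cccc(-c3c[nH]nn3)c2)c1` gives 261 mL.min-1.g-1, a number within the usual scatter of compound 1 and clearly higher than that of compound 2.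

The next compound, compound 4 `CC(F)(F)c1cccc(N2C(=O)CSC2c2cccc(C(=O)NCCCCc3ccccc3)c2)c1`, differs from compound 3 in one group: 1,1-difluoroethyl in place of 1H-1,2,3-triazol-4-yl on an aromatic carbon. In short, 1,1-difluoroethyl stands in place of 1H-1,2,3-triazol-4-yl on an aromatic carbon. For the measured compounds named here, no measured pair makes this exact exchange. The nearest evidence is a 3.3-fold lower number from compound 1 to compound 2 (0.51 log units; beyond the scatter), where 4-methylpyridin-2-yl replaces 5-fluoro-2-methoxyphenyl on an amide-type nitrogen in a ring. That step shows that a single exchange can shift the number modestly, but it involves other groups and gives no firm direction here. Compounds 1 and 2 also carry a different amide side chain from compound 3. A modest step is therefore the most that can reasonably be expected, with a slight lean upward, and it may well stay within the scatter. The expected change is a 1.3-fold higher number from compound 3 to compound 4 (0.10 log units; within the scatter). For compound 4 the estimated value is 330 mL.min-1.g-1, with an expected range from 150 mL.min-1.g-1 to 700 mL.min-1.g-1.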

Compound 4, intrinsic clearance in microsomes: 1750 mL.min-1.g-1
Compound 4: middle estimate off by 5.3-fold (0.72 log units), on the low side; the whole stated range lies below it.
By their numbers in this assay, from the lowest: compound 2; then compounds 3 and 1 (each within the scatter of the next); then compound 4.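

In this assay, putting 1,1-difluoroethyl in place of 1H-1,2,3-triazol-4-yl gives a 6.7-fold higher number from compound 3 to compound 4 (0.83 log units; beyond the scatter) and so shows that this place, on an aromatic carbon of a six-membered aromatic ring of carbon only and meta to a large group, has a clear bearing on the number. The earlier step exchanged the whole group on the amide-type nitrogen, whereas here that ring stays and the amide side chain stays too, so one group on the ring is enough to carry the number beyond the scatter. The exchange replaces a five-membered aromatic ring that has hydrogen-bond donor and acceptor atoms with an open group that has none, and no measurement at hand tells which of these differences counts.

As far as these compounds go, it remains open whether the rise follows from losing the triazole or from gaining the two fluorines, a question that a methyl, an ethyl or a plain hydrogen at this place would help to settle. From the compounds shown here alone, it is equally open whether a carboxylic acid or an amine here would move the number the same way, or whether this exchange would do so with the amide side chain of compound 1.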